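A hydroxy group on the core of compound 1

A few compounds are considered here, and "the series" means these few. Any claim that something is new, unique, unknown or untested is made for them only; others in the source may bear on it.

Measured in an ADME assay on HEK293 cells (Homo sapiens) for cytotoxicity, read by CellTiter-Glo, with a stated time of 72 h; on this read-out lower numbers stand for an effect already at smaller amounts and higher numbers for an effect only at larger amounts of compound 
Compound 1 `CC1=C2CC(C)(C)/C=C/C/C(C)=C\C3=C[C@H](C)C[C@]3(O2)C1=O` gives 26000 nM 
Compound 2 `CC1=C2CC(C)(C)/C=C/C(=O)/C(C)=C\C3=C[C@H](C)C[C@]3(O2)[C@]1(C)O` gives 26000 nM 

In this assay, among the measured compounds shown here, compound 1 stands level with compound 2, the only other compound measured, and their two values show no difference. Compound 3 `CC1=C2CC(C)(C)/C=C/[C@@H](O)/C(C)=C\C3=C[C@H](C)C[C@]3(O2)C1=O` still awaits measurement. It differs from compound 1 by one change hydroxy in place of hydrogen on a saturated ring carbon in which hydroxy takes the place of hydrogen on a saturated ring carbon. For the measured compounds named here, no pair of measured compounds differing in one place is available, so the data offer no direct guide to this change. With compound 1 at 26000 nM and level with compound 2, no step beyond the scatter is expected in this assay and no direction is favoured. The estimate for the step of no change at the digits printed from compound 1 to compound 3 (within the scatter) reflects this expectation. Compound 3 is expected at 26000 nM (estimated range 11000 nM to 60000 nM).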

Compound 3, half-maximal effective concentration: 26000 nM
For compound 3 middle estimate and measured number coincide at the digits printed; the measured number falls inside the stated range.
By their numbers in this assay, from the lowest: compounds 1, 2 and 3 (each within the scatter of the next).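

Hydroxy in place of hydrogen on a saturated ring carbon gives no change at the digits printed from compound 1 to compound 3 (within the scatter) in this assay and is the first single change in this set that can be read directly. Compound 2 could not show this, as it differs from compound 1 in more than one place. At this position, next to the ring atom that bears a methyl group, the added hydroxy therefore leaves the read-out within the scatter, and no measurement offered here explains that result.

The compounds shown leave open whether a larger group on this carbon, such as a methoxy group, an amine or a carboxylic acid, would also stay level with compound 1. They also leave open whether the opposite spatial arrangement of the hydroxy group would do so.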